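Swapping a chlorophenyl amide for a pyridyl amide

This account rests on a few compounds, and the source may have more. Where it says the series, first, only, none or still open, it means among the compounds named here.

In an in vitro functional assay on HEK293-A cells for antagonist activity at metabotropic glutamate receptor 5 (Rattus norvegicus), read by calcium flux (a lower number here means a stronger inhibitor, a higher number a weaker inhibitor), compound 1 `O=C(Nc1cccc(O)c1)c1cccc(N2C(=O)c3ccccc3C2=O)c1` gives 7790 nM. For the measured compounds named here, compound 2 `O=C(Nc1cccc(Cl)c1)c1cccc(N2C(=O)c3ccccc3C2=O)c1` gives 1780 nM in this assay, and the single step between them, a 4.4-fold lower number from compound 1 to compound 2 (0.64 log units; beyond the scatter), comes from putting chloro in place of hydroxy on an aromatic carbon. Going by the values given here, compound 2 therefore holds the lowest of the two numbers measured so far, with compound 1 as its only neighbour at a higher value.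

Compound 3 `O=C(Nc1cccnc1)c1cccc(N2C(=O)c3ccccc3C2=O)c1` differs from compound 2 by pyridin-3-yl in place of 3-chlorophenyl on an amide-type nitrogen. Among the compounds with values here, no measured step touches this exact exchange; the only step known, a 4.4-fold lower number from compound 1 to compound 2 (0.64 log units; beyond the scatter), concerns a different group at the same amide end, and it shows that removing the chlorine in favour of a group that can take part in hydrogen bonding raised the number. On that basis compound 3 is expected to give a somewhat higher number than compound 2, a step of about a 2.8-fold higher number from compound 2 to compound 3 (0.45 log units; beyond the scatter). The estimate for compound 3 is 5000 nM, with a range from 1500 nM to 16000 nM.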

Compound 3, half-maximal inhibitory concentration: > 30000 nM
Compound 3: only a limit was reported; the forecaster's own chance of this, stated with the estimate: 20%; middle value at least 6.0-fold (0.77 log units) away from the limit.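

At this amide-type nitrogen the aromatic ring cannot be exchanged freely: in this assay, pyridin-3-yl in place of 3-chlorophenyl gives an at least 16-fold higher number from compound 2 to compound 3 (1.22 log units; beyond the scatter), and pyridin-3-yl in place of 3-hydroxyphenyl gives an at least 3.8-fold higher number from compound 1 to compound 3 (0.58 log units; beyond the scatter). From the compounds shown here alone, compound 3 is reported only as a limit, so both steps are minimum sizes and its actual number remains unknown: the limit of > 30000 nM in this assay, at which 1 of the 3 values shown sits. The earlier pair changed only a substituent on a phenyl ring, whereas this exchange alters the ring itself and removes the chlorine as well.

The compounds shown cannot separate the loss of the chlorine from the entry of the ring nitrogen. An unsubstituted phenyl ring, or a pyridin-3-yl ring carrying chloro, could help tell those two changes apart.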